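This account rests on a few compounds, and the source may have more. Where it says the series, first, only, none or still open, it means among the compounds named here.

Series in a functional assay on U-87MG ATCC cells for antiproliferative activity against U-87 MG (Homo sapiens), read by MTT assay, with a stated time of 48 h; a lower number here means a stronger inhibitor, a higher number a weaker inhibitor:
- Compound 1 `C#CCOC(=O)/C(C)=C/CC/C(C)=C/CC/C(C)=C/CC[C@@H]1[C@@]2(C)CCC(=O)C(C)(C)[C@H]2CC[C@@]1(C)O`: > 150000 nM, a limit of the assay
- Compound 2 `C/C(=C\CC/C(C)=C/CC[C@@H]1[C@@]2(C)CCC(=O)C(C)(C)[C@H]2CC[C@@]1(C)O)CC/C=C(\C)C(=O)OCc1cn(-c2cccc(Cl)c2)nn1`: 91800 nM
- Compound 3 `C/C(=C\CC/C(C)=C/CC[C@@H]1[C@@]2(C)CCC(=O)C(C)(C)[C@H]2CC[C@@]1(C)O)CC/C=C(\C)C(=O)OCc1cn(-c2cccc(F)c2)nn1`: not yet measured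

Within the data shown here, compound 2, at 91800 nM, holds the only actual number so far. For compound 1 the assay reports only a limit: the limit of > 150000 nM in this assay, at which 1 of the 2 values shown sits.

The next change keeps the shared core and the ester chain of compound 2 and alters only the aryl group on the triazole. Compound 3 has fluoro in place of chloro on an aromatic carbon, meta to a large group: fluoro in place of chloro on an aromatic carbon.

Among the measured compounds shown here, only one measured step exists, an at least 1.6-fold lower number from compound 1 to compound 2 (0.21 log units; that floor lies within the scatter). For the measured compounds named here, it places 1-(3-chlorophenyl)-1H-1,2,3-triazol-4-yl where compound 1 has ethynyl, so it does not test the halogen, and no measured pair varies that position. With nothing to set a direction, no step beyond the scatter is expected in this assay. The expected step is a 1.1-fold higher number from compound 2 to compound 3 (0.04 log units; within the scatter). A reading at the limit would not be a surprise.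

Compound 3 is estimated at 100000 nM, with an expected range of 55000 nM to 150000 nM.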

Compound 3, half-maximal inhibitory concentration: > 150000 nM
Compound 3 ended at the assay's limit; the forecaster's own chance of this, stated with the estimate: 25%; middle value at least 1.5-fold (0.17 log units) from the limit.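

In this assay, fluoro in place of chloro on an aromatic carbon gives an at least 1.6-fold higher number from compound 2 to compound 3 (0.21 log units; that floor lies within the scatter). Among these compounds, this is the first measured change at the halogen, but compound 3 gives only a limit, so the true size of the step stays unknown and the data do not show that the two halogens differ beyond the scatter. The step between compound 1 and compound 3 cannot be read, as both are limits, and the limit now dominates the series: the limit of > 150000 nM in this assay, at which 2 of the 3 values shown sit.

Among the compounds shown here, compound 2 remains the only compound with an actual number, so the series offers no measured trend at this position and no way to rank the halogens. On these data alone, it remains open whether bromo, methoxy or a nitrile on that aromatic carbon, or an unsubstituted phenyl on the triazole, would give a value clear of the limit, and whether an amide in place of the ester would do the same.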